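This account rests on a few compounds, and the source may have more. Where it says the series, first, only, none or still open, it means among the compounds named here.

Working notes on the series. Compound 2 `O=C(NCc1ccc(CNS(=O)(=O)c2ccccc2Cl)cc1)c1cccnc1` stands at the lowest of the two numbers in hand: in an assay on MDA-MB-231 cells for displacement of a labelled ligand from C-X-C chemokine receptor type 4 (Homo sapiens), read by fluorescence and microscopy, with stated times of 10 min and 30 min (a lower number here means that less compound is needed, a higher number that more compound is needed for the effect), compound 2 gives 100 nM. For the measured compounds named here, the only other measured member, compound 1 `COc1ccccc1C(=O)NCc1ccc(CNS(=O)(=O)c2ccccc2C)cc1`, gives 1000 nM in this assay, a gap that lies beyond the scatter. Going by the values given here, no pair that differs in one place has been measured, so no single step size is known.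

Compound 3 `COc1ccccc1C(=O)NCc1ccc(CNS(=O)(=O)c2ccccc2Cl)cc1` is not yet measured. Relative to compound 2 the change is 2-methoxyphenyl in place of pyridin-3-yl on a carbonyl carbon. Among the compounds with values here, the incoming group is the one carried by compound 1, whose higher value in this assay is 1000 nM. Compound 1 also differs from compound 2 elsewhere. The two measured numbers do not show this change on its own.

An increase in the number is expected from compound 2 to compound 3, of moderate size, a 3.0-fold higher number from compound 2 to compound 3 (0.48 log units; beyond the scatter), because compound 1 with the same carbonyl substituent gives 1000 nM while compound 2 gives 100 nM. The estimate for compound 3 in this assay is 300 nM, within the range 100 nM to 1000 nM.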

Compound 3, effective concentration (reported as EC, without a stated level of effect): 100 nM
Estimate against measurement, compound 3: 3.0-fold (0.48 log units) above; measured number inside the range.
By their numbers in this assay, from the lowest: compounds 2 and 3 (each within the scatter of the next); then compound 1.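

In this assay the exchange of pyridin-3-yl for 2-methoxyphenyl on a carbonyl carbon now reads on its own as no change at the digits printed from compound 2 to compound 3 (within the scatter) and so gives the first single-place result at this position, where the two groups cannot be told apart with chloro held in place on the aromatic ring of the sulfonamide side. For the compounds shown here, the other single-place comparison, chloro in place of methyl on an aromatic carbon with 2-methoxyphenyl held on the carbonyl carbon, reads a 10-fold lower number from compound 1 to compound 3 (1.00 log units; beyond the scatter) and is the only one of the two steps that lies beyond the scatter. No measurement in hand offers an explanation for either step.

The compounds shown leave open whether the exchange of chloro and methyl has the same size with pyridin-3-yl on the carbonyl carbon, and whether the carbonyl substituent stays without effect when methyl replaces chloro. They also leave open what a fluoro or trifluoromethyl group would give in place of chloro, and what an aliphatic amine would give in place of the aromatic ring on the carbonyl carbon.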